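The compounds below may be only part of what the source reports. "The series", "measured", "known", "first", "only" and "open" are said of these compounds alone.

Measured compounds:
- compound 1, `COc1ccc(-c2nnc(SCC(=O)Nc3ccc(/C(C)=N/O)cc3)n2-c2ccccc2)cc1`, 57%
- compound 2, `CCn1c(SCC(=O)Nc2ccc(C(C)=O)cc2)nnc1-c1ccc(OC)cc1`, 57%
- compound 3, `C=CCn1c(SCC(=O)Nc2ccc(C(C)=O)cc2)nnc1-c1ccc(OC)cc1`, 52%

In a functional assay on the whole organism (strain albino) for inhibition, with Rattus norvegicus as the target, read by paw edema, with stated times of 30 min and 3 h, at a dose of 0.28 mmol/kg by the oral route (on this read-out higher numbers stand for more inhibition at the one dose given (going by the name of the read-out) and lower numbers for less inhibition), compound 3 gives 52%, the lowest of the three numbers, yet compound 1 and compound 2 each sit only a few points away from it, so all three lie within the usual scatter of one another.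

Compound 4, `COc1ccc(-c2nnc(SCC(=O)Nc3ccc(C(C)=O)cc3)n2-c2ccccc2)cc1`, has not been measured. It differs from compound 3 in one place: phenyl in place of allyl on an aromatic nitrogen.

For the measured compounds named here, the only measured step at this nitrogen is a number 5 percentage points lower from compound 2 to compound 3 (within the scatter), which lies within the scatter. Compound 1 carries the same phenyl group on that nitrogen and gives 57%, while compound 3, with allyl there, gives 52%; these two values also lie within the scatter of each other. Going by the values given here, nothing among the measured compounds therefore points to a change beyond the scatter from allyl to phenyl at this position. For compound 4 the expected step is a number 4 percentage points higher from compound 3 to compound 4 (within the scatter). Compound 4 is estimated at 56%, with a likely range from 46% to 66%.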

Compound 4, a percentage reported as inhibition, in the whole organism at one dose (the size of the read-out at that dose, not a potency): 58%
Compound 4: middle estimate off by 2 percentage points, on the low side; the range from low to high includes it.
By their numbers in this assay, from the lowest: compounds 3, 1, 2 and 4 (each within the scatter of the next).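

In this assay, phenyl on the aromatic nitrogen can now be compared directly with two smaller groups on the same core: against allyl the result is a number 6 percentage points higher from compound 3 to compound 4 (within the scatter), and against ethyl it is a number 1 percentage points higher from compound 2 to compound 4 (within the scatter). Ethyl, allyl and phenyl are therefore not told apart at this position at this one dose, even though phenyl brings in a six-membered aromatic ring. With phenyl held fixed, changing the group on the aromatic carbon from the oxime to the acetyl gives a number 1 percentage points higher from compound 1 to compound 4 (within the scatter), so that change is not told apart either.

No measured evidence bears on why these compounds read alike. On these data alone, whether an amine, a carboxylic acid or a longer chain on this nitrogen would move the number beyond the scatter remains open.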